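A few compounds are considered here, and "the series" means these few. Any claim that something is new, unique, unknown or untested is made for them only; others in the source may bear on it.

In a functional assay on L5178Y cells (Mus musculus) for cytotoxicity, read by MTT assay (a lower number here means a stronger inhibitor, a higher number a weaker inhibitor), compound 1 `CC(C)(C)c1ccc(OCCCCN2CCN(c3ncccn3)CC2)cc1` gives 20.8 nM. Two companions differ from it only in the group on the amine nitrogen in the ring: compound 2 `CC(C)(C)c1ccc(OCCCCN2CCN(c3cccnc3)CC2)cc1` gives 11.7 nM, and compound 3 `CC(C)(C)c1ccc(OCCCCN2CCN(c3cnccn3)CC2)cc1` gives 18.3 nM. Compound 1 thus holds the highest of the three numbers, yet the steps away from it, a 1.8-fold lower number from compound 1 to compound 2 (0.25 log units; within the scatter) and a 1.1-fold lower number from compound 1 to compound 3 (0.06 log units; within the scatter), both lie within the scatter, as does a 1.6-fold higher number from compound 2 to compound 3 (0.19 log units; within the scatter). The three values therefore sit in one narrow band with no ordering among them.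

Compound 4 `CCC(C)(C)c1ccc(OCCCCN2CCN(c3ncccn3)CC2)cc1` has not yet been measured. It differs from compound 1 by methyl in place of hydrogen on a saturated chain carbon, two bonds along the chain from an aromatic carbon; read one bond further out, the change is tert-butyl to 1,1-dimethylpropyl. For the measured compounds named here, none of the measured steps bears on this part of the molecule: all three exchange the ring on the amine nitrogen and leave the tert-butyl group untouched, so there is no precedent here for growing that chain. With nothing pointing either way, no step beyond the scatter is expected, and a 1.0-fold lower number from compound 1 to compound 4 (0.02 log units; within the scatter) is the expected step. For compound 4 the estimate is 20 nM, with a range from 8 nM to 50 nM.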

Compound 4, half-maximal inhibitory concentration: 46.4 nM
For compound 4 the middle estimate is 2.3-fold (0.37 log units) below the measured one; low and high end bracket the measured number.
By their numbers in this assay, from the lowest: compounds 2, 3 and 1 (each within the scatter of the next); then compound 4.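

In this assay, the exchanges of the ring on the amine nitrogen all stayed within the scatter, whereas this first change at the other end of the molecule goes beyond it, with a 2.2-fold higher number from compound 1 to compound 4 (0.35 log units; beyond the scatter), though the step is modest. The position is therefore not silent: replacing tert-butyl with 1,1-dimethylpropyl, a single added methyl on a saturated chain carbon, leaves compound 4 a weaker inhibitor than compound 1. Nothing available accounts for this step.

From the compounds shown here alone, whether the number keeps rising with a longer chain at this position, such as 1,1-dimethylbutyl, or responds differently to a smaller isopropyl group, remains open. Also open, going by these compounds, is whether the same added methyl gives a similar step when the amine nitrogen carries pyridin-3-yl or pyrazin-2-yl.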